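The source may report more compounds than this note shows. Statements on the series, on what has been measured and on what is new or still open speak of the compounds shown alone.

Compound 1 `COc1ccc(COC(=O)N(c2ccccc2)C2CN3CCC2CC3)cc1F` is the reference point of this account. In an assay on CHO cells for displacement of a labelled ligand from muscarinic acetylcholine receptor M5 (Homo sapiens), read by scintillation counting, with a stated time of 2 h (on this read-out higher numbers stand for weaker inhibition and lower numbers for stronger inhibition), compound 1 gives 40 nM, the lowest number among the three measured compounds. Compound 3 `COc1ccc(CCCOC(=O)N(c2ccccc2)C2CN3CCC2CC3)cc1F` gives 260 nM in this assay, and compound 2 `COc1ccc(CCOC(=O)N(c2ccccc2)C2CN3CCC2CC3)cc1OC` gives 3490 nM. Among the compounds with values here, the only single-point step among the measured compounds runs a 13-fold lower number from compound 2 to compound 3 (1.13 log units; beyond the scatter), with 3-fluoro-4-methoxybenzyl in place of 3,4-dimethoxyphenyl on a saturated chain carbon, two bonds along the chain from an oxygen next to a carbonyl group.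

Compound 4 `O=C(OCc1ccccc1)N(c1ccccc1)C1CN2CCC1CC2` has not yet been measured. Relative to compound 1 the change is phenyl in place of 3-fluoro-4-methoxyphenyl on a saturated chain carbon bound to an oxygen next to a carbonyl group. Within the data shown here, no measured step removes both substituents from the aryl group, so the bearing of the existing data is indirect. The step from compound 2 to compound 3 shows that the substitution pattern on the aryl group can move the number sharply, but that step also alters the chain, so it is only loosely related. With compound 1 at 40 nM and compound 3 at 260 nM, a modest move toward a higher number is considered more likely than none. For compound 4 the expected step is a 2.5-fold higher number from compound 1 to compound 4 (0.40 log units; beyond the scatter). Compound 4 is therefore estimated at 100 nM, with a range from 25 nM to 500 nM.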

Compound 4, inhibition constant: 150 nM
Compound 4: middle estimate off by 1.5-fold (0.18 log units), on the low side, within the range that was stated.
By their numbers in this assay, from the lowest: compound 1; then compounds 4 and 3 (each within the scatter of the next); then compound 2.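

In this assay, within the data shown here, the change to phenyl gives a 3.8-fold higher number from compound 1 to compound 4 (0.57 log units; beyond the scatter) and so offers the first reading at this position in which the aryl group alone differs, on a saturated chain carbon bound to an oxygen next to a carbonyl group. The earlier step also altered the chain and could not separate the two kinds of change, whereas this one ties a modest difference, beyond the scatter, to the loss of the 3-fluoro-4-methoxyphenyl group with the rest of compound 1 left intact. It also shows that the substituents are not needed for a measurable number, as compound 4 with its bare phenyl still gives 150 nM in this assay, and nothing available here explains the size of the step.

The compounds shown leave open how the step divides between the fluorine and the methoxy group, a question that 3-fluorophenyl and 4-methoxyphenyl at this place would address. They also leave open whether another group there, such as 4-chlorophenyl or a pyridine ring, would match or go beyond the 3-fluoro-4-methoxyphenyl group of compound 1.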